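Sulfonyl variation within the aryl-alkyne phenoxyacetic acid series

The source may hold more compounds than are shown below. What is called first, only, known or untested is meant among the compounds shown, and "the series" means these compounds.

In an assay on CHO cells for displacement of a labelled ligand from prostaglandin D2 receptor 2 (Homo sapiens), read by scintillation counting (on this read-out lower numbers stand for stronger inhibition and higher numbers for weaker inhibition), compound 1 `O=C(O)COc1ccc(Cl)cc1C#Cc1ccccc1C(F)(F)F` gives 24 nM and compound 3 `CCCS(=O)(=O)c1cccc(C#Cc2c(OCC(=O)O)cccc2-c2sc(C)nc2C)c1` gives 54 nM. Compound 2 `Cc1ccc(S(=O)(=O)N(C)C(C)C)cc1C#Cc1cc(Cl)ccc1OCC(=O)O` gives 3.8 nM, the lowest of the three numbers, and its gaps to compound 1 and to compound 3 both lie beyond the scatter. Compound 4 `Cc1ccc(S(C)(=O)=O)cc1C#Cc1cc(Cl)ccc1OCC(=O)O` differs from compound 2 in a single place: methyl in place of isopropyl(methyl)amino on a sulfonyl sulfur. For the measured compounds named here, no measured pair shows this change, so the size of the step rests on expectation alone. A modest rise in the number is expected from compound 2 to compound 4, a 2.6-fold higher number from compound 2 to compound 4 (0.42 log units; beyond the scatter), small enough that compound 4 should stay well inside the range spanned by the three measured compounds. In this assay compound 4 is expected to give about 10 nM, with a likely range of 3 nM to 35 nM.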

Compound 4, inhibition constant: 5 nM
Beside the measured number, compound 4's estimate is 2.0-fold (0.30 log units) above it; low and high end bracket the measured number.
By their numbers in this assay, from the lowest: compounds 2 and 4 (each within the scatter of the next); then compound 1; then compound 3.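

In this assay the step is a 1.3-fold higher number from compound 2 to compound 4 (0.12 log units; within the scatter) and so shows no real difference between the two groups on the sulfonyl sulfur. At this place, a low number does not depend on the five heavy atoms of isopropyl(methyl)amino, since the single carbon of methyl gives a value within the scatter. Nothing measured bears on why the two compounds read alike.

From the compounds shown here alone, whether larger groups on the sulfur, such as a morpholine or a phenyl ring, also hold the number remains open. So does the effect of replacing the whole sulfonyl group with a nitrile or a carboxylic acid.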